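This account rests on a few compounds, and the source may have more. Where it says the series, first, only, none or still open, it means among the compounds named here.

Compound 1 `O=C(O)c1ccccc1-c1ccc(CCc2ncc(Cc3ccccc3F)[nH]2)cc1`: 9.5 nM
Compound 2 `O=C(O)c1ccccc1-c1ccc(CCc2ncc(CCC3CCCCC3)[nH]2)cc1`: 33 nM
Compound 3 `Cc1ccc(Cc2cnc(CCc3ccc(-c4ccccc4C(=O)O)cc3)[nH]2)cc1`: 162 nM

These values come from an in vitro functional assay on cells for agonist activity at Bombesin receptor subtype-3 (Mus musculus), read by luminescence and calcium flux; a higher number here means that more compound is needed for the effect, a lower number that less compound is needed. Compound 2 gives the second highest number of the three: a 3.5-fold higher number from compound 1 to compound 2 (0.54 log units; beyond the scatter), and a 4.9-fold higher number from compound 2 to compound 3 (0.69 log units; beyond the scatter). Compound 4 `O=C(O)c1ccccc1-c1ccc(CCc2ncc(Cc3cccc(F)c3F)[nH]2)cc1` has not been measured. Its difference from compound 2 is 2,3-difluorophenyl in place of cyclohexylmethyl on a saturated chain carbon bound to an aromatic carbon. The step that bears on this change is the one in this assay with a 3.5-fold higher number from compound 1 to compound 2 (0.54 log units; beyond the scatter), where 2-fluorophenyl gave the lower number and cyclohexylmethyl the higher. Compound 4 returns to a fluorinated phenyl, now carrying two fluorines, so a modest step back to a lower number is expected, a 2.8-fold lower number from compound 2 to compound 4 (0.44 log units; beyond the scatter). Compound 4 is therefore estimated at 12 nM, with a range from 4 nM to 40 nM.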

Compound 4, half-maximal effective concentration: 8 nM
Compound 4: middle estimate off by 1.5-fold (0.18 log units), on the high side, within the range that was stated.
By their numbers in this assay, from the lowest: compounds 4 and 1 (each within the scatter of the next); then compound 2; then compound 3.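

A second fluoro on the aromatic ring, as 2,3-difluorophenyl, gives a number that cannot be told apart from that of the 2-fluorophenyl compound (a 1.2-fold lower number from compound 1 to compound 4 (0.07 log units; within the scatter)) in this assay. The fluorinated phenyl groups therefore both stay clearly ahead of cyclohexylmethyl (a 4.1-fold lower number from compound 2 to compound 4 (0.62 log units; beyond the scatter)) and further ahead of 4-methylphenyl (a 20-fold lower number from compound 3 to compound 4 (1.31 log units; beyond the scatter)). Nothing measured here gives a cause for these steps.

Still open, going by these compounds, is whether chlorine or a methoxy group on this phenyl ring would keep the number as low as fluoro does.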